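Swapping the aroyl cap for a sulfonyl cap on the ring nitrogen

The compounds below may be only part of what the source reports. "The series", "measured", "known", "first", "only" and "open" are said of these compounds alone.

Three compounds share one core and differ only in what sits on an amine nitrogen in a ring. Compound 1 `CN(C)c1ccc(C2CC(c3ccc(-n4cncn4)cc3)=NN2)cc1` carries a hydrogen there; in a functional assay on NCI-H1975 cells (Homo sapiens) for inhibition, read by sulforhodamine B assay, tested at 10 uM (a higher number here means more inhibition at the concentration tested (going by the name of the read-out), a lower number less inhibition), compound 1 gives -3.3%. Compound 2 `CC(=O)N1N=C(c2ccc(-n3cncn3)cc2)CC1c1ccc(N(C)C)cc1` carries an acetyl in that place, and in this assay compound 2 gives -0.3%, which is a number 3 percentage points higher from compound 1 to compound 2 (within the scatter). Compound 3 `CN(C)c1ccc(C2CC(c3ccc(-n4cncn4)cc3)=NN2C(=O)c2ccc(C(F)(F)F)cc2)cc1` carries a (4-(trifluoromethyl)phenyl)carbonyl on that nitrogen; in this assay compound 3 gives 11.5%, the highest of the three numbers, reached by a number 14.8 percentage points higher from compound 1 to compound 3 (beyond the scatter) and by a number 11.8 percentage points higher from compound 2 to compound 3 (beyond the scatter).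

Compound 4 `CN(C)c1ccc(C2CC(c3ccc(-n4cncn4)cc3)=NN2S(=O)(=O)c2ccc(F)cc2)cc1` continues from compound 3 with one change: (4-fluorophenyl)sulfonyl in place of (4-(trifluoromethyl)phenyl)carbonyl on an amine nitrogen in a ring. Among the measured compounds shown here, no measured step puts a sulfonyl on this nitrogen, so the two steps to compound 3 bear on it only indirectly: both show that a larger aromatic cap on this nitrogen has so far gone with modestly more inhibition than a hydrogen or an acetyl, and compound 4 keeps such a cap. A step beyond the scatter in either direction is therefore not expected. In this assay compound 4 is expected to give about 8%, within a range from -6% to 22%. That estimate means an expected step of a number 3.5 percentage points lower from compound 3 to compound 4 (within the scatter), within the scatter.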

Compound 4, a percentage reported as inhibition, at one concentration (the size of the read-out at that concentration, not a potency): -0.5%
Estimate against measurement, compound 4: 8.5 percentage points above, and the stated range covers the measured number.
By their numbers in this assay, from the lowest: compounds 1, 4 and 2 (each within the scatter of the next); then compound 3.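

Keeping an aromatic cap on this ring nitrogen is not enough to hold the small gain in inhibition: both the leaving and the entering group carry one six-membered aromatic ring, yet the swap to (4-fluorophenyl)sulfonyl gives a number 12 percentage points lower from compound 3 to compound 4 (beyond the scatter) in this assay and so removes that gain. Set against the smaller groups, the sulfonyl cap stands apart from neither: in place of acetyl it gives a number 0.2 percentage points lower from compound 2 to compound 4 (within the scatter) and in place of hydrogen it gives a number 2.8 percentage points higher from compound 1 to compound 4 (within the scatter) so among these four caps only the (4-(trifluoromethyl)phenyl)carbonyl stands clear of the others, and the rise does not extend to aromatic caps in general. No measurement is available to explain this result.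

The swap changes two things at once, the carbonyl link becoming a sulfonyl link and the trifluoromethyl on the aromatic ring becoming a fluorine, and the compounds shown cannot separate the two. A (4-fluorophenyl)carbonyl or a (4-(trifluoromethyl)phenyl)sulfonyl on this nitrogen would each change only one of them, and would show which one goes with the step.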